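A Furan Ring Replaces Thiophene on a Shared Nucleoside Core

A few compounds are considered here, and "the series" means these few. Any claim that something is new, unique, unknown or untested is made for them only; others in the source may bear on it.

Compound 3 `CNc1ncnc2c1c(-c1cccs1)cn2[C@@H]1O[C@H](CO)[C@@H](O)[C@H]1O` was tested in a functional assay on HCT-116 cells (Homo sapiens), read by MTT assay, with a stated time of 72 h; a higher number here means a weaker inhibitor, a lower number a stronger inhibitor. In this assay compound 3 gives only a limit, > 20000 nM, and not a number. Compound 1 `Cc1ncnc2c1c(-c1ccoc1)cn2[C@@H]1O[C@H](CO)[C@@H](O)[C@H]1O` likewise gives only a limit in this assay, > 20000 nM. Compound 2 `CNc1ncnc2c1c(I)cn2[C@@H]1O[C@H](CO)[C@@H](O)[C@H]1O` also gives a limit, > 100000 nM. All three values shown are therefore limits: the limit of > 20000 nM in this assay, at which 2 of the 3 values shown sit, and (the limit of > 100000 nM in this assay, at which 1 of the 3 values shown sits). Among the measured compounds shown here, the single step among measured compounds, a step that the two limits leave unreadable from compound 2 to compound 3, is unreadable in size.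

Compound 4 `CNc1ncnc2c1c(-c1ccoc1)cn2[C@@H]1O[C@H](CO)[C@@H](O)[C@H]1O` differs from compound 3 by furan-3-yl in place of thiophen-2-yl on an aromatic carbon. For the measured compounds named here, no measured step bears on this change, and no measured value lies within the readable range of this assay, so there is nothing from which a step of a particular size or direction could be expected. Compound 4 is thus expected to sit at or near the limit as well, estimated at 30000 nM with a range from 8000 nM to 120000 nM. The step this estimate means, a step that the limit leaves unreadable from compound 3 to compound 4, is expected to lie within the scatter.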

Compound 4, half-maximal inhibitory concentration: > 20000 nM
Compound 4 gave a limit, no number; the forecaster's own chance of this, stated with the estimate: 80%; the middle value lies beyond the limit too.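

In this assay compound 4 gives only a limit, > 20000 nM. Its steps from compound 1, compound 2 and compound 3 cannot be read. With only limits shown, the compounds leave open whether any of these changes on the shared core alters the half-maximal inhibitory concentration at all.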